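A few compounds are considered here, and "the series" means these few. Any claim that something is new, unique, unknown or untested is made for them only; others in the source may bear on it.

Measured in an assay on isolated protein for binding affinity to corticotropin-releasing factor receptor 1 (Homo sapiens); on this read-out lower numbers stand for stronger inhibition and higher numbers for weaker inhibition:
compound 1 `CC(=O)/C(=N\Nc1ccccc1)Oc1cccc(Cl)c1` – a limit only, > 10000 nM;
compound 2 `CSc1cccc(N/C(=N/Nc2ccccc2C)C(C)=O)c1` – a limit only, > 10000 nM;
compound 3 `COc1cccc(N/C(=N/Nc2ccccc2Cl)C(C)=O)c1` – 652 nM.

Compound 3 thus stands as the only measured number in this assay among these three; the other two values are covered by the limit of > 10000 nM in this assay, at which 2 of the 3 values shown sit, which is a limit of the assay and not a number. A limit offers no number to compare, so nothing is said here about how compound 3 ranks against compound 1 or compound 2. Compound 4 `CSc1cccc(N/C(=N/Nc2ccccc2Cl)C(C)=O)c1` differs from compound 3 in a single respect: methylsulfanyl in place of methoxy on an aromatic carbon. Methylsulfanyl also appears in compound 2, but that compound differs from compound 4 on the other ring as well, so no single step joins them. Among the compounds with values here, with no measured step of this kind, the change from compound 3 to compound 4 is expected to be a 1.8-fold higher number from compound 3 to compound 4 (0.26 log units; within the scatter), a modest weakening near the edge of the scatter. Compound 4 is accordingly estimated at 1200 nM, with a range from 300 nM to 6000 nM.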

Compound 4, inhibition constant: > 10000 nM
Compound 4 ended at the assay's limit (the forecaster's own chance of this, stated with the estimate: 25%); middle value at least 8.3-fold (0.92 log units) from the limit.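

Methylsulfanyl in place of methoxy, on an aromatic carbon meta to a large group, is the first single change here that can be read, and it gives an at least 15-fold higher number from compound 3 to compound 4 (1.18 log units; beyond the scatter) in this assay. With the rest of the molecule held fixed, this position therefore tolerates no free swap between these two groups of equal heavy-atom count, and the measurable binding of compound 3 depends on the methoxy. Compound 4 gives a limit and not a number, and the step from compound 2, chloro in place of methyl, cannot be read: the limit of > 10000 nM in this assay, at which 3 of the 4 values shown sit.

As far as these compounds go, how far the number for compound 4 really lies from that of compound 3 stays open. So does whether a hydroxy, an ethoxy or an amine at this carbon would keep a measurable value.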